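A few compounds are considered here, and "the series" means these few. Any claim that something is new, unique, unknown or untested is made for them only; others in the source may bear on it.

Working notes on the series. Three compounds carry the same core: compound 1 `C=C(Br)C(=O)Nc1cccc(-c2cn3nc(-c4ccc(F)cc4)sc3n2)c1`, compound 2 `C=C(Br)C(=O)Nc1cccc(-c2cn3nc(Cc4cccc(OC)c4)sc3n2)c1` and compound 3 `C=C(Br)C(=O)Nc1cccc(-c2cn3nc(Cc4ccc(Cl)cc4)sc3n2)c1`. In a functional assay on FM3A cells (Mus musculus) for inhibition, read by cell counting, with a stated time of 2 days (a lower number here means a stronger inhibitor, a higher number a weaker inhibitor), compound 1 gives 610 nM. In this assay compound 2 gives 1100 nM. In this assay compound 3 gives 1100 nM. Compound 3 therefore sits level with compound 2, the two together being the highest of the three numbers, and the step of a 1.8-fold higher number from compound 1 to compound 3 (0.26 log units; within the scatter) stays within the scatter, as does a 1.8-fold higher number from compound 1 to compound 2 (0.26 log units; within the scatter). The next compound, compound 4 `C=C(Br)C(=O)Nc1cccc(-c2cn3nc(CCc4ccccc4)sc3n2)c1`, differs from compound 3 by benzyl in place of 4-chlorophenyl on a saturated chain carbon bound to an aromatic carbon. The step that bears on this most directly is the earlier swap of the aryl on that same saturated chain carbon, no change at the digits printed from compound 2 to compound 3 (within the scatter); it showed nothing beyond the scatter, and the two steps from compound 1 to its benzyl analogues were likewise small. No step beyond the scatter is therefore expected, a 1.1-fold lower number from compound 3 to compound 4 (0.04 log units; within the scatter) being the estimated outcome. On that basis compound 4 is estimated at 1000 nM in this assay, with an expected range of 500 nM to 2200 nM.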

Compound 4, half-maximal inhibitory concentration: 2600 nM
Compound 4: the middle estimate sits 2.6-fold (0.41 log units) below what was measured; the whole stated range lies below it.
By their numbers in this assay, from the lowest: compounds 1, 2 and 3 (each within the scatter of the next); then compound 4.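

In this assay, the saturated chain carbon bound to an aromatic carbon had shown no change between 3-methoxyphenyl and 4-chlorophenyl, but benzyl at that place gives a 2.4-fold higher number from compound 3 to compound 4 (0.37 log units; beyond the scatter) and a 2.4-fold higher number from compound 2 to compound 4 (0.37 log units; beyond the scatter). Measured against the aryl group of the core of compound 1, phenethyl gives a 4.3-fold higher number from compound 1 to compound 4 (0.63 log units; beyond the scatter), whereas 3-methoxybenzyl and 4-chlorobenzyl both stayed within the scatter, so this position does respond to the group carried there, though the steps remain modest. No measurement at hand bears on the reason for this rise.

The change from 4-chlorobenzyl to phenethyl alters the chain and removes the chlorine at once, and the two contributions cannot be separated from these compounds. As far as these compounds go, how a 4-chlorophenethyl group, a 3-phenylpropyl chain or an amine on the chain would read in this assay remains open.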